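Adding a methyl to a ring amine nitrogen

This account rests on a few compounds, and the source may have more. Where it says the series, first, only, none or still open, it means among the compounds named here.

In a functional assay on NCI-H1975 cells (Homo sapiens) for antiproliferative activity (on this read-out higher numbers stand for weaker inhibition and lower numbers for stronger inhibition), compound 1 (`Cc1c2c(n3c1CCCN[C@@H](C)[C@H](C)Nc1cc-3ccc1C(N)=O)CC(C)(C)CC2=O`) gives 20 nM and compound 2 (`Cc1c2c(n3c1CCNC[C@@H](C)[C@H](C)Nc1cc-3ccc1C(N)=O)CC(C)(C)CC2=O`) gives 27 nM, so the two values lie within the usual scatter of each other. Compound 3 (`Cc1c2c(n3c1CCCN(C)[C@@H](C)[C@H](C)Nc1cc-3ccc1C(N)=O)CC(C)(C)CC2=O`) differs from compound 1 in one place: methyl in place of hydrogen on an amine nitrogen in a ring. For the measured compounds named here, no measured pair shows what this change does in this assay, so the forecast is uncertain. A moderate move towards weaker inhibition is expected, which is a higher number. The expected step is a 3.0-fold higher number from compound 1 to compound 3 (0.48 log units; beyond the scatter). For compound 3, the estimated value is 60 nM, with an expected range of 15 nM to 250 nM.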

Compound 3, half-maximal inhibitory concentration: 69 nM
Compound 3: middle estimate off by 1.2-fold (0.06 log units), on the low side; low and high end bracket the measured number.
By their numbers in this assay, from the lowest: compounds 1 and 2 (each within the scatter of the next); then compound 3.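

In this assay, replacing the hydrogen on this ring amine nitrogen with a methyl gives a 3.5-fold higher number from compound 1 to compound 3 (0.54 log units; beyond the scatter), so this single added carbon has a real, if modest, cost. The position therefore tolerates the methyl only in part, since compound 3 still gives 69 nM. Nothing available here explains the loss. Still open, from the compounds shown here alone, is whether an ethyl or an acetyl on this nitrogen would move the number further in the same direction. Also open, going by these compounds, is whether a methyl on the amine nitrogen of compound 2 would give a similar step.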